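A few compounds are considered here, and "the series" means these few. Any claim that something is new, unique, unknown or untested is made for them only; others in the source may bear on it.

In a functional assay (QGY7701 cells, Homo sapiens) for inhibition, read by MTT assay, with a stated time of 48 h (on this read-out lower numbers stand for stronger inhibition and higher numbers for weaker inhibition), two compounds have been measured so far. Compound 1 `COc1ccc2c(=O)c(/C=C/C(=O)Nc3cc(C)ccc3C)coc2c1` gives only a limit of the assay, > 100000 nM. Going by the values given here, compound 2 `Cc1ccccc1NC(=O)/C=C/c1coc2cc(O)ccc2c1=O` gives 9320 nM, the only numerical value obtained. Compound 3 `O=C(/C=C/c1coc2cc(O)ccc2c1=O)Nc1ccccc1` differs from compound 2 in one place: hydrogen in place of methyl on an aromatic carbon. Among the compounds with values here, no pair of measured compounds differs in a single place, so no measured step shows what this change does. The step from compound 2 to compound 3 is expected to stay within the usual scatter, a 1.3-fold higher number from compound 2 to compound 3 (0.11 log units; within the scatter). Compound 3 is thus estimated at 12000 nM, between 4000 nM and 40000 nM.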

Compound 3, half-maximal inhibitory concentration: 17900 nM
Estimate against measurement, compound 3: 1.5-fold (0.17 log units) below, within the range that was stated.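

In this assay, hydrogen in place of methyl on this aromatic carbon gives a 1.9-fold higher number from compound 2 to compound 3 (0.28 log units; within the scatter). Going by these compounds alone, this is the first measured step at this position, and it shows that compound 3 still gives a number without the methyl, so the 2-methylphenyl group is not required for a measurable value. Within the data shown here, nothing measured so far offers an explanation for this step. The compounds shown leave open whether an amine, a carboxylic acid or a longer chain at this position would change the number beyond the scatter. From the compounds shown here alone, what a chlorine would do elsewhere on this ring also stays open.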